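The compounds below may be only part of what the source reports. "The series", "measured", "known", "first", "only" and "open" are said of these compounds alone.

Working notes on the series. Compound 1 `O=C(Nc1cccc(-n2cc(-c3ccncc3)c(-c3ccc(Cl)c(O)c3)n2)c1)Nc1ccc(Cl)c(Cl)c1` carries a urea that joins the shared core to a 3,4-dichlorophenyl group. In a functional assay on HCT-116 cells (Homo sapiens) for inhibition, read by sulforhodamine B assay, with a stated time of 48 h (on this read-out lower numbers stand for higher toxicity in this test and higher numbers for lower toxicity in this test), compound 1 returns only the assay limit, > 32500 nM, so no number stands for it. Compound 2 `COc1cc(-c2nn(-c3cccc(NC(=O)c4ccccc4)c3)cc2-c2ccncc2)ccc1Cl`, which carries an amide instead, likewise returns only a limit in this assay, at > 100000 nM. Both values shown are limits, the limit of > 100000 nM in this assay, at which 1 of the 2 values shown sits, and (the limit of > 32500 nM in this assay, at which 1 of the 2 values shown sits), so compound 1 cannot be placed relative to compound 2 on the numbers. Compound 3 `O=C(Nc1cccc(-n2cc(-c3ccncc3)c(-c3ccc(Cl)c(O)c3)n2)c1)Nc1ccc(Cl)c(C(F)(F)F)c1` differs from compound 1 by trifluoromethyl in place of chloro on an aromatic carbon. Within the data shown here, no step between measured compounds exists to gauge this change. Since compound 1 sits at a limit, no shift beyond the usual scatter in this assay is expected. The expected step is a step that the limit leaves unreadable from compound 1 to compound 3. Compound 3 is estimated at 40000 nM, between 15000 nM and 110000 nM, most likely again reported as a limit.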

Compound 3, concentration lethal to 50% of the cells: > 32500 nM
Compound 3 was reported as a limit (the forecaster's own chance of this, stated with the estimate: 70%); the middle value lies beyond the limit too.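

Compound 1 and compound 3 each return only a limit in this assay, so no step can be read between them: the limit of > 32500 nM in this assay, at which 2 of the 3 values shown sit.

As far as these compounds go, what trifluoromethyl in place of chloro does in this assay stays open, as does any ranking of compound 1, compound 2 and compound 3.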